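The source may report more compounds than this note shows. Statements on the series, on what has been measured and on what is new or still open speak of the compounds shown alone.

Going by the values given here, compound 3 `O=[N+]([O-])c1cccc(-c2csc(NS(=O)(=O)c3ccc(Cl)cc3)n2)c1` is one of three compounds measured in an assay on isolated protein for inhibition of kynurenine 3-monooxygenase (Rattus norvegicus) (a lower number here means a stronger inhibitor, a higher number a weaker inhibitor), where compound 3 gives 84 nM. Compound 1 `Cc1ccc(S(=O)(=O)Nc2nc(-c3ccc(Cl)c(Cl)c3)cs2)cc1` gives 56 nM, and compound 2 `Cc1ccc(S(=O)(=O)Nc2nc(-c3ccc(O)c(C)c3)cs2)cc1` gives 114 nM. Compound 3 lies within the usual scatter of both of these numbers, so on the numbers shown it cannot be placed clearly above or below either of its neighbours. Among the compounds with values here, the only measured step, a 2.0-fold higher number from compound 1 to compound 2 (0.31 log units; beyond the scatter), arises from 4-hydroxy-3-methylphenyl in place of 3,4-dichlorophenyl on an aromatic carbon, a different part of the shared core. Compound 4 `COc1ccc(S(=O)(=O)Nc2nc(-c3cccc([N+](=O)[O-])c3)cs2)cc1` differs from compound 3 by methoxy in place of chloro on an aromatic carbon, which one bond further out reads 4-chlorophenyl to 4-methoxyphenyl. Within the data shown here, no measured pair changes that ring alone; compounds 1 and 3, which differ there and elsewhere, give numbers within the scatter of each other. Compound 4 is therefore expected to show a step of about a 1.4-fold higher number from compound 3 to compound 4 (0.15 log units; within the scatter), no larger than the scatter itself. The estimate for compound 4 is 120 nM, with a range from 50 nM to 300 nM.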

Compound 4, half-maximal inhibitory concentration: 51 nM
Compound 4: the middle estimate sits 2.4-fold (0.37 log units) above what was measured, within the range that was stated.
By their numbers in this assay, from the lowest: compounds 4, 1, 3 and 2 (each within the scatter of the next, the first and the last beyond it).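

In this assay, going by these compounds alone, the pair of compound 3 and compound 4 gives the first reading of a change to this ring alone, with the rest of the molecule held the same: methoxy in place of chloro gives a 1.6-fold lower number from compound 3 to compound 4 (0.22 log units; within the scatter). At this place, para to a large group, two heavy atoms including a hydrogen-bond acceptor can therefore stand in place of a single chlorine with no difference that can be told from the scatter. Nothing measured here speaks to why these two groups give such close numbers.

Going by these compounds, it remains open whether an amine, a carboxylic acid or a longer chain such as butoxy at this place would give a step beyond the scatter. Also open, on these data alone, is whether methoxy in place of chloro would read the same on a compound carrying the 3,4-dichlorophenyl group of compound 1.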